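The compounds below may be only part of what the source reports. "The series", "measured", "known", "first", "only" and "open" are said of these compounds alone.

Three close relatives share one core and differ only in the group on one aromatic carbon: compound 1 `C#Cc1cn([C@@H]2O[C@H](CO)[C@@H](O)[C@H]2O)c2ncnc(C)c12`, compound 2 `C#Cc1cn([C@@H]2O[C@H](CO)[C@@H](O)[C@H]2O)c2ncnc(NC)c12` and compound 3 `C#Cc1cn([C@@H]2O[C@H](CO)[C@@H](O)[C@H]2O)c2ncnc(OC)c12`. In a functional assay on A549 cells (Homo sapiens), read by MTT assay, with a stated time of 72 h (a lower number here means a stronger inhibitor, a higher number a weaker inhibitor), compound 1 gives 19200 nM. In this assay compound 3 gives 8160 nM, a change of a 2.4-fold lower number from compound 1 to compound 3 (0.37 log units; beyond the scatter). For compound 2 this assay reports only a limit, > 20000 nM, as the limit of > 20000 nM in this assay, at which 1 of the 3 values shown sits, states. That leaves an at least 1.0-fold higher number from compound 1 to compound 2 (0.01 log units; that floor lies within the scatter) and an at least 2.4-fold lower number from compound 2 to compound 3 (0.38 log units; beyond the scatter) as the other measured steps, both of which touch the same position as the first.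

Compound 4 `CNc1ncnc2c1c(-c1ccoc1)cn2[C@@H]1O[C@H](CO)[C@@H](O)[C@H]1O` keeps the methylamino group of compound 2 and changes a different place: furan-3-yl in place of ethynyl on an aromatic carbon. Going by the values given here, none of the three measured steps alters the ethynyl group, so no measured step bears directly on this change, and the expectation rests on compound 2 alone. Since compound 2 sits at a limit in this assay, the expected step of an at least 1.1-fold lower number from compound 2 to compound 4 (0.04 log units; that floor lies within the scatter) is taken as none beyond the scatter, with wide uncertainty. Compound 4 is therefore estimated at 18000 nM, within 4000 nM to 80000 nM.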

Compound 4, half-maximal inhibitory concentration: > 20000 nM
Compound 4 gave a limit, no number (the forecaster's own chance of this, stated with the estimate: 50%); middle value at least 1.1-fold (0.04 log units) away from the limit.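

Compound 2 and compound 4 both end at a limit rather than a number, so no step between them can be read: the limit of > 20000 nM in this assay, at which 2 of the 4 values shown sit.

The compounds shown leave open whether furan-3-yl in place of ethynyl changes the result in this assay at all.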